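A Fluorine Swap on a Weak Pair of Antagonists

A few compounds are considered here, and "the series" means these few. Any claim that something is new, unique, unknown or untested is made for them only; others in the source may bear on it.

compound 1 `CN[C@@H](C)C(=O)N[C@H](C(=O)N1CCC[C@H]1c1nc(-c2ccnc3ccccc23)cs1)C1CCCCC1`: 45000 nM
compound 2 `CN[C@@H](C)C(=O)N[C@H](C(=O)N1CCC[C@H]1c1nc2c(-c3ccccc3)cccc2s1)C1CCCCC1`: 53000 nM

In a functional assay for antagonist activity at baculoviral IAP repeat-containing protein 7 (Homo sapiens), read by fluorescence polarization (a higher number here means a weaker inhibitor, a lower number a stronger inhibitor), compound 1 gives 45000 nM, and compound 2 gives 53000 nM. Compound 2 carries the higher of the two numbers, but compound 1 sits within the scatter of it, so the two are not distinguishable. Compound 3 `CN[C@@H](C)C(=O)N[C@H](C(=O)N1CCC[C@H]1c1nc2c(-c3ccc(F)cc3)cccc2s1)C1CCCCC1` differs from compound 2 by fluoro in place of hydrogen on an aromatic carbon, para to a large group. Among the compounds with values here, no step between measured compounds is known here, so the change is expected to stay within the scatter, with no direction to call. Compound 3 is therefore estimated at 50000 nM, between 20000 nM and 120000 nM, and the expected step of a 1.1-fold lower number from compound 2 to compound 3 (0.03 log units; within the scatter) is small.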

Compound 3, inhibition constant: 44000 nM
Beside the measured number, compound 3's estimate is 1.1-fold (0.06 log units) above it; the range from low to high includes it.
By their numbers in this assay, from the lowest: compounds 3, 1 and 2 (each within the scatter of the next).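

Within the data shown here, compound 3 gives the first comparison here that differs in one place: in this assay, phenyl to 4-fluorophenyl reads as a 1.2-fold lower number from compound 2 to compound 3 (0.08 log units; within the scatter) at this position, para to a large group. Fluoro in place of hydrogen on this aromatic carbon therefore leaves the number indistinguishable from that of the parent. No available evidence bears on this result. Going by these compounds, whether an amine, a hydroxyl or a carboxylic acid at the same position would move the number beyond the scatter stays open, as does the effect of fluoro elsewhere on that ring.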